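Dropping the Distal Methoxy from Compound 2

A few compounds are considered here, and "the series" means these few. Any claim that something is new, unique, unknown or untested is made for them only; others in the source may bear on it.

Measured so far:
- Compound 1, `COc1ccccc1N1CCN(CCCC(=O)NC2CCCc3c(OC)cccc32)CC1`: in an assay on HEK293 cells for displacement of a labelled ligand from 5-hydroxytryptamine receptor 7 (Rattus norvegicus) (on this read-out higher numbers stand for weaker inhibition and lower numbers for stronger inhibition), compound 1 gives 35 nM.
- Compound 2, `COc1ccc2c(c1)C(NC(=O)CCCN1CCN(c3ccccc3OC)CC1)CCC2`: in this assay compound 2 gives 129 nM.

Among the compounds with values here, only two compounds have numbers in this assay, and compound 2 has the higher of them; its nearest neighbour, compound 1, sits well below it, and that gap lies beyond the scatter of repeated measurements. The two differ only in where a methoxy sits on the shared core, but that pair is not treated as a single step here, so nothing is read into it beyond the two values themselves.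

Compound 3, `COc1ccccc1N1CCN(CCCC(=O)NC2CCCc3ccccc32)CC1`, is the methoxy-free analogue of compound 2. The change is hydrogen in place of methoxy on an aromatic carbon, at a site meta to a fused ring and para to a fused ring. Within the data shown here, no matching step between measured compounds exists, so the expectation rests on the two values alone. Compound 3 is expected to land between those two numbers, somewhat closer to compound 2, that is a step of a 1.8-fold lower number from compound 2 to compound 3 (0.27 log units; within the scatter), a modest improvement at the edge of the scatter. The estimate for compound 3 is 70 nM, with a plausible range from 25 nM to 200 nM.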

Compound 3, inhibition constant: 92 nM
For compound 3 the middle estimate is 1.3-fold (0.12 log units) below the measured one; low and high end bracket the measured number.
By their numbers in this assay, from the lowest: compound 1; then compounds 3 and 2 (each within the scatter of the next).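

In this assay, methoxy and hydrogen cannot be told apart at this site on the aromatic ring of the shared core: the step reads a 1.4-fold lower number from compound 2 to compound 3 (0.15 log units; within the scatter). The same exchange made on compound 1, where the methoxy sits elsewhere on that ring, can be read, as a 2.6-fold higher number from compound 1 to compound 3 (0.42 log units; beyond the scatter). Across these three compounds, then, what the exchange does depends on where the methoxy stands, and only the methoxy of compound 1 goes with a number clearly separated from that of the unsubstituted compound 3.

As far as these compounds go, it remains open whether a different group at either site, such as a hydroxyl, a fluorine atom or an ethoxy, would separate from hydrogen in this assay, and whether the site of compound 2 tolerates such groups as evenly as it does the methoxy. Nothing available here bears on what lies behind the difference between the two sites.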